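This account rests on a few compounds, and the source may have more. Where it says the series, first, only, none or still open, it means among the compounds named here.

Measured compounds in a functional assay on MCF7 cells (Homo sapiens) for antiproliferative activity, read by MTT assay, with a stated time of 72 h; on this read-out higher numbers stand for weaker inhibition and lower numbers for stronger inhibition:
compound 1 `CCN1CCN(c2cc(C)c3cc(NC(=O)c4cccc(Cl)c4)ccc3n2)CC1` gives 3820 nM
compound 2 `CCN(CC)CCNc1cc(C)c2cc(NC(=O)c3ccc(Cl)c(Cl)c3)ccc2n1` gives 1420 nM
compound 3 `Cc1cc(N(C)C)nc2ccc(NC(=O)c3ccc(Cl)c(Cl)c3)cc12` gives 33300 nM

On these three numbers compound 1 stands second highest: compound 2 gives a lower number, compound 3 a higher one. Compound 1 and compound 2 differ in more than one place, so their values are noted side by side without a step. Within the data shown here, the single counted step in the set, a 23-fold higher number from compound 2 to compound 3 (1.37 log units; beyond the scatter), concerns the amine on the shared core and was large; it says nothing about the amide side.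

Compound 4 `CCN1CCN(c2cc(C)c3cc(NC(=O)c4ccc(OC)cc4)ccc3n2)CC1` is the next compound. The change from compound 1 reads (4-methoxyphenyl in place of 3-chlorophenyl on a carbonyl carbon). Among the measured compounds shown here, no measured step touches this part of the molecule: the only amide variation in the set, between compound 1 and compound 2, is confounded with a change of amine. The step from compound 1 to compound 4 is therefore anchored only on compound 1 itself, with 3820 nM as the reference point.

Given the lack of a bearing step, the expected step is a 1.6-fold higher number from compound 1 to compound 4 (0.20 log units; within the scatter), which is estimated to be modest and may not exceed the scatter. Compound 4 is estimated at 6000 nM in this assay, with a range from 2000 nM to 18000 nM.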

Compound 4, half-maximal inhibitory concentration: 7690 nM
For compound 4 the middle estimate is 1.3-fold (0.11 log units) below the measured one, and the stated range covers the measured number.
By their numbers in this assay, from the lowest: compound 2; then compounds 1 and 4 (each within the scatter of the next); then compound 3.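

Among these compounds, with the amine on the shared core held fixed, this assay gives a first reading of the amide side: a 2.0-fold higher number from compound 1 to compound 4 (0.30 log units; within the scatter). This exchange of 3-chlorophenyl for 4-methoxyphenyl on a carbonyl carbon swaps the chlorine for an oxygen-bearing group and moves the substituent on the ring, yet the step stays within the scatter, whereas the amine step, a 23-fold higher number from compound 2 to compound 3 (1.37 log units; beyond the scatter), lies beyond it. No measurement on hand offers an explanation for the size of either step.

On these data alone, a single step cannot separate the identity of the substituent from its place on the ring, and it remains open whether an unsubstituted phenyl, a 4-chlorophenyl or a 3-methoxyphenyl on the same carbonyl carbon would give a step beyond the scatter. As far as these compounds go, it also remains open whether the amide side behaves the same way with the (2-(diethylamino)ethyl)amino group of compound 2, which gives 1420 nM but differs from compound 1 in more than one place.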